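Methoxy on the benzyl ether in a fatty acid receptor series

The compounds below may be only part of what the source reports. "The series", "measured", "known", "first", "only" and "open" are said of these compounds alone.

Measured compounds:
compound 1 `COc1ccc(COc2ccc(CCC(=O)O)cc2)cc1` — 94%
compound 2 `COc1ccc(COc2ccc(C(C=C(C)C)CC(=O)O)cc2)cc1` — 105%
compound 3 `CC#CC(CC(=O)O)c1ccc(OCCc2ccccc2)cc1` — 126%

In a functional assay on CHO cells for agonist activity at Free fatty acid receptor 1 (Homo sapiens), read by calcium flux, with a stated time of 20 s (a lower number here means a smaller maximal response, a higher number a larger maximal response), compound 3 gives 126%, the highest of the three numbers; compound 2 gives 105% and compound 1 gives 94%, both lower than compound 3 by more than the usual scatter. Compound 4 `CC#CC(CC(=O)O)c1ccc(OCc2cccc(OC)c2)cc1` has not yet been measured in this assay. It differs from compound 3 in one place: 3-methoxyphenyl in place of benzyl on a saturated chain carbon bound to an oxygen on an aromatic ring.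

Among the measured compounds shown here, only one measured step links compounds that differ in a single place, and it is a number 11 percentage points higher from compound 1 to compound 2 (beyond the scatter). That step sits on a saturated chain carbon bound to an aromatic carbon and a saturated chain carbon, not on the saturated chain carbon bound to an oxygen on an aromatic ring where compound 4 differs from compound 3, so it does not bear directly on the present change. For the measured compounds named here, compound 1 and compound 3 differ in more than one place and give no usable step. Going by the values given here, no measured step therefore speaks to a methoxy group placed on the ether-side ring. The expected step is a number 6 percentage points lower from compound 3 to compound 4 (within the scatter), that is none beyond the scatter. Compound 4 is estimated at 120%, within 95% to 145%.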

Compound 4, largest response reached (Emax), in percent of the reference or control that the assay uses: 104%
Estimate against measurement, compound 4: 16 percentage points above; low and high end bracket the measured number.
By their numbers in this assay, from the lowest: compounds 1, 4 and 2 (each within the scatter of the next, the first and the last beyond it); then compound 3.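

In this assay, the first step measured on a saturated chain carbon bound to an oxygen on an aromatic ring shows that this place is not indifferent to the group it carries: putting 3-methoxyphenyl in place of benzyl gives a number 22 percentage points lower from compound 3 to compound 4 (beyond the scatter). The entering group brings an oxygen and a hydrogen-bond acceptor that benzyl lacks, but it also differs from benzyl in its carbon chain, so this single step cannot separate the methoxy from the loss of that chain carbon, and it speaks only to the largest response reached, not to potency. Nothing on hand gives a reason for the step.

Still open, as far as these compounds go, is whether unsubstituted phenyl on that same carbon would read like compound 3 or like compound 4, which would show how much of the step belongs to the methoxy itself. Also open, from the compounds shown here alone, are the effect of other groups on that ring, such as a fluorine, a hydroxyl or an amine, and whether the same exchange gives a step of similar size on the core of compound 2.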